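The source may hold more compounds than are shown below. What is called first, only, known or untested is meant among the compounds shown, and "the series" means these compounds.

Compound 1 `COc1ccc(-c2cn(CC3=C(Cl)c4ccc(-c5cccs5)nc4CC3)nn2)cc1` was assessed in an ADME assay on MDCK cells (Canis lupus familiaris) for cytotoxicity, read by MTT assay, with a stated time of 48 h; a lower number here means that less compound is tolerated, a higher number that more compound is tolerated. Here compound 1 reaches only the assay limit of > 300 ug/mL, so its standing is known as a limit rather than a number (the limit of > 300 ug/mL in this assay, at which 1 of the 2 values shown sits). Within the data shown here, compound 2 `Fc1ccc(-c2cn(CC3=C(Cl)c4ccc(-c5cccs5)nc4CC3)nn2)c(F)c1` gives 188 ug/mL in this assay, and the step of an at least 1.5-fold lower number from compound 1 to compound 2 (0.20 log units; that floor lies within the scatter) is the sole measured comparison available. Compound 3 `O=[N+]([O-])c1ccc(-c2cn(CC3=C(Cl)c4ccc(-c5cccs5)nc4CC3)nn2)cc1` differs from compound 1 by nitro in place of methoxy on an aromatic carbon. Among the measured compounds shown here, since the one measured step stayed within the scatter, no step beyond the scatter is expected for compound 3 in this assay. For compound 3 the estimated value is 250 ug/mL, ranging from 120 ug/mL to 450 ug/mL. This estimate means an expected step of an at least 1.2-fold lower number from compound 1 to compound 3 (0.07 log units; that floor lies within the scatter).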

Compound 3, half-maximal cytotoxic concentration: 40 ug/mL
Estimate against measurement, compound 3: 6.3-fold (0.80 log units) above; measured number below the stated range.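

Unlike the earlier change at this aromatic carbon, the 4-nitrophenyl group moves this assay beyond the scatter, with an at least 7.5-fold lower number from compound 1 to compound 3 (0.87 log units; beyond the scatter) as the step from the 4-methoxyphenyl group. The 2,4-difluorophenyl group is also separated from it, with a 4.7-fold lower number from compound 2 to compound 3 (0.67 log units; beyond the scatter) on the same shared core, so less of compound 3 is tolerated than of either earlier compound. Compound 1 stands at a limit, so its step is only a floor: the limit of > 300 ug/mL in this assay, at which 1 of the 3 values shown sits. The compounds shown leave open how an amine or a carboxylic acid would behave at this position. They also leave open whether a nitrile would track the nitro result.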